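A few compounds are considered here, and "the series" means these few. Any claim that something is new, unique, unknown or untested is made for them only; others in the source may bear on it.

Of the compounds shown here, three sharing one core have been tested in a functional assay on HeLa cells (Homo sapiens) for cytotoxicity, read by MTT assay, with a stated time of 48 h; on this read-out lower numbers stand for stronger inhibition and higher numbers for weaker inhibition. Compound 1 `CCOC(=O)c1c(-c2cc3ccccc3oc2=O)nn(-c2ccccc2)c1C(=O)OCC` gives 100000 nM, compound 2 `CCOC(=O)c1c(-c2cc3ccccc3oc2=O)nn(-c2cccc(C)c2)c1C(=O)OCC` gives 245000 nM, and compound 3 `CCOC(=O)c1c(-c2cc3ccc(OC)cc3oc2=O)nn(-c2ccccc2)c1C(=O)OCC` gives 140000 nM. Compound 3 therefore stands second highest of the three numbers, within the scatter of both compound 1 and compound 2. Compound 4 `CCOC(=O)c1c(-c2cc3ccc(OC)cc3oc2=O)nn(-c2cccc(C)c2)c1C(=O)OCC` differs from compound 3 by methyl in place of hydrogen on an aromatic carbon. The same change has been measured once on the parent core, where a 2.5-fold higher number from compound 1 to compound 2 (0.39 log units; beyond the scatter) was seen, a modest step beyond the scatter; the added methoxy in compound 3 gave only a 1.4-fold higher number from compound 1 to compound 3 (0.15 log units; within the scatter). A rise of similar modest size is thus expected, namely a 2.5-fold higher number from compound 3 to compound 4 (0.40 log units; beyond the scatter). Compound 4 is accordingly estimated at 350000 nM, expected between 140000 nM and 900000 nM.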

Compound 4, half-maximal inhibitory concentration: 35000 nM
Beside the measured number, compound 4's estimate is 10-fold (1.00 log units) above it, outside the stated range (below it).
By their numbers in this assay, from the lowest: compound 4; then compounds 1, 3 and 2 (each within the scatter of the next, the first and the last beyond it).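

In this assay, the effect of the methyl reverses once the methoxy is present, with a 4.0-fold lower number from compound 3 to compound 4 (0.60 log units; beyond the scatter), so the change from phenyl to 3-methylphenyl does not carry over from one core to the other: the same change on two cores in this assay, a 2.5-fold higher number (0.39 log units; beyond the scatter) from compound 1 to compound 2 and a 4.0-fold lower number (0.60 log units; beyond the scatter) from compound 3 to compound 4, 9.8-fold (0.99 log units) apart, beyond the scatter of two such steps

The methoxy likewise behaves differently with the methyl present, giving a 7.0-fold lower number from compound 2 to compound 4 (0.85 log units; beyond the scatter): the same change on two cores in this assay, a 1.4-fold higher number (0.15 log units; within the scatter) from compound 1 to compound 3 and a 7.0-fold lower number (0.85 log units; beyond the scatter) from compound 2 to compound 4, 9.8-fold (0.99 log units) apart, beyond the scatter of two such steps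

Across these four compounds, the two changes therefore do not add.

As far as these compounds go, it remains open whether another group in the methyl's place, such as an ethyl, a chlorine or an amine, would follow compound 4 or compound 2. The compounds shown also cannot tell what lies behind the reversal.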